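Furan for Benzofuran on Two Nucleoside Cores

This account rests on a few compounds, and the source may have more. Where it says the series, first, only, none or still open, it means among the compounds named here.

Compound 1 `CNc1ncnc2c1c(-c1cc3ccccc3o1)cn2[C@@H]1O[C@H](CO)[C@@H](O)[C@H]1O` gives in a functional assay on HCT-116 cells (Homo sapiens), read by MTT assay, with a stated time of 72 h (on this read-out lower numbers stand for stronger inhibition and higher numbers for weaker inhibition), only a limit, > 20000 nM, not a number.
Compound 2 `CNc1ncnc2c1c(-c1ccco1)cn2[C@@H]1O[C@H](CO)[C@@H](O)[C@H]1O` gives in this assay 440 nM.
Compound 3 `Nc1nc(N)c2c(-c3cc4ccccc4o3)cn([C@@H]3O[C@H](CO)[C@@H](O)[C@H]3O)c2n1` gives in this assay 14000 nM.
Compound 4 `Nc1nc(N)c2c(-c3ccco3)cn([C@@H]3O[C@H](CO)[C@@H](O)[C@H]3O)c2n1` has not yet been measured.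

On the core of compound 1, the change furan-2-yl in place of 1-benzofuran-2-yl on an aromatic carbon produced an at least 45-fold lower number from compound 1 to compound 2 (1.65 log units; beyond the scatter). For the measured compounds named here, compound 3 rests on a different core; the difference between the two cores is not broken down here, and the two values show only that compound 3 returns a number while compound 1 sits at the limit of > 20000 nM in this assay, at which 1 of the 3 values shown sits.

Compound 4 carries the same change, (furan-2-yl in place of 1-benzofuran-2-yl on an aromatic carbon), on the core of compound 3, at a place described in the same words as before. The step from compound 3 to compound 4 is expected to be a 35-fold lower number from compound 3 to compound 4 (1.54 log units; beyond the scatter), resting on the earlier step because compound 2 gives 440 nM and compound 3 already returns a number rather than a limit. Compound 4 is therefore expected to give about 400 nM in this assay, most likely between 100 nM and 2000 nM.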

Compound 4, half-maximal inhibitory concentration: > 20000 nM
Compound 4 was reported as a limit (the forecaster's own chance of this, stated with the estimate: 5%); middle value at least 50-fold (1.69 log units) from the limit.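

On the core of compound 3, furan-2-yl in place of 1-benzofuran-2-yl on an aromatic carbon gives an at least 1.4-fold higher number from compound 3 to compound 4 (0.15 log units; that floor lies within the scatter) in this assay. Compound 4 gives > 20000 nM, which is a limit and not a number. The lower number seen on the core of compound 1 thus does not carry over to the core of compound 3, although two cores alone cannot show which feature of the core decides the outcome: the same change on two cores in this assay, an at least 45-fold lower number (1.65 log units; beyond the scatter) from compound 1 to compound 2 and an at least 1.4-fold higher number (0.15 log units; that floor lies within the scatter) from compound 3 to compound 4, at least 64-fold (1.81 log units) apart, beyond the scatter of two such steps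

The compounds shown leave open whether any other group at this aromatic carbon, such as thiophen-2-yl or a plain phenyl ring, would return a number on either core. They also leave open how the furan-2-yl group would behave on a further core carrying, for example, a dimethylamino group, so the split between compound 2 and compound 4 rests on this one pair of cores.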